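The source may hold more compounds than are shown below. What is called first, only, known or untested is meant among the compounds shown, and "the series" means these compounds.

Three compounds have been measured in a functional assay on L1210 cells (Mus musculus) for antiproliferative activity; a higher number here means a more potent compound, by a factor of ten per unit of this negative logarithm, a lower number a less potent compound:
compound 1, `CN(C)/N=N/c1ccc([N+](=O)[O-])cc1C(N)=O`, gives 3.26;
compound 2, `CCCCN(C)/N=N/c1c(C(N)=O)n[nH]c1C`, gives 3.83;
compound 3, `Cc1[nH]nc(C(N)=O)c1/N=N/N(C)C`, gives 3.84.

Compound 3 and compound 2 differ in one place only, (propyl in place of hydrogen on a saturated chain carbon bound to an amine nitrogen), and that change made a number 0.01 log units lower from compound 3 to compound 2 (within the scatter). Compound 1 stands lowest of the three, with compound 2 and compound 3 lying beyond the scatter above it. Compound 4, `CCCCN(C)/N=N/c1ccc([N+](=O)[O-])cc1C(N)=O`, is not yet measured. It differs from compound 1 by the same change, (propyl in place of hydrogen on a saturated chain carbon bound to an amine nitrogen), made on a different core; the difference between the core of compound 1 and the core of compound 3 is not broken down here. Within the data shown here, the only measured instance of this change, a number 0.01 log units lower from compound 3 to compound 2 (within the scatter), stayed within the scatter, so the step from compound 1 to compound 4 in this assay is expected to be similarly small, no change at the digits printed from compound 1 to compound 4 (within the scatter). On that basis compound 4 is expected to give 3.26, most likely between 2.96 and 3.56.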

Compound 4, logarithm of the reciprocal of the active concentration, log(1/C): 3.08
Compound 4: the middle estimate sits 0.18 log units above what was measured, and the stated range covers the measured number.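

In this assay the swap of dimethylamino for butyl(methyl)amino gave a number 0.18 log units lower from compound 1 to compound 4 (within the scatter) and so behaved on this core as it did on the core of compound 3: the same change on two cores in this assay, a number 0.01 log units lower (within the scatter) from compound 3 to compound 2 and a number 0.18 log units lower (within the scatter) from compound 1 to compound 4, 0.17 log units apart, within the scatter of two such steps

Across these two pairs, then, the change carries from one core to the other with no step that can be told from the scatter. Two pairs are few, however, and a small real difference between the cores could lie hidden in that scatter, so the two cores are not shown to respond identically.

The compounds shown leave open whether a chain longer than butyl, or a chain carrying an amine or a carboxylic acid, would leave the number as little moved. They also leave open whether the change behaves the same way on any other core.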